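The source may report more compounds than this note shows. Statements on the series, on what has been measured and on what is new or still open speak of the compounds shown alone.

Measured so far:
compound 1, `COc1cc(-c2ccnc3cc(-c4ccc(C)c(C)c4)nn23)cc(OC)c1OC`: 272 nM
compound 2, `COc1cc(-c2ccnc3cc(-c4ccc(C(F)(F)F)cc4)nn23)cc(OC)c1OC`: 2070 nM

In a functional assay on A549 cells (Homo sapiens) for inhibition, read by CCK-8 assay, with a stated time of 48 h (a higher number here means a weaker inhibitor, a lower number a stronger inhibitor), compound 2 gives 2070 nM, the higher of the two numbers; its nearest neighbour, compound 1, gives 272 nM. For the measured compounds named here, the single step measured, a 7.6-fold higher number from compound 1 to compound 2 (0.88 log units; beyond the scatter), shows that exchange of the aryl group at this position moves this assay by a modest amount beyond the scatter.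

Compound 3, `COc1cc(-c2ccnc3cc(-c4ccc5cnn(C)c5c4)nn23)cc(OC)c1OC`, differs from compound 2 in one place: 1-methyl-1H-indazol-6-yl in place of 4-(trifluoromethyl)phenyl on an aromatic carbon. Going by the values given here, no measured pair shows a 1-methyl-1H-indazol-6-yl group entering or leaving, so nothing fixes the direction of this change directly; the only guide is the width of the one aryl exchange already seen. The expected step of a 3.0-fold lower number from compound 2 to compound 3 (0.47 log units; beyond the scatter) is a moderate lowering, judged plausible because a 7.6-fold higher number from compound 1 to compound 2 (0.88 log units; beyond the scatter) shows the trifluoromethylphenyl compound carrying the higher number. The estimate for compound 3 is 700 nM, with a range from 180 nM to 2700 nM.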

Compound 3, half-maximal inhibitory concentration: 233 nM
Compound 3: the middle estimate sits 3.0-fold (0.48 log units) above what was measured; measured number inside the range.
By their numbers in this assay, from the lowest: compounds 3 and 1 (each within the scatter of the next); then compound 2.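

In this assay, the exchange at this position also works in the lowering direction: 1-methyl-1H-indazol-6-yl in place of 4-(trifluoromethyl)phenyl gives an 8.9-fold lower number from compound 2 to compound 3 (0.95 log units; beyond the scatter). A group with a five-membered aromatic ring carrying hetero atoms can also match 3,4-dimethylphenyl here, as the exchange between them gives a 1.2-fold lower number from compound 1 to compound 3 (0.07 log units; within the scatter), within the scatter, so a ring of carbon only is not required among these three compounds. Compound 2 now stands apart from both other compounds, but no supporting data bear on why.

As far as these compounds go, it remains open whether the trifluoromethyl group itself sets compound 2 apart, since a single methyl or a chlorine on the phenyl ring would be needed to separate that group from the loss of the second methyl. Also open, from the compounds shown here alone, is how an amine or a carboxylic acid on this aryl group would behave in this assay.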